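The source may report more compounds than this note shows. Statements on the series, on what has been measured and on what is new or still open speak of the compounds shown alone.

Three compounds share one core and have been measured in a functional assay on GTL 16 cells for antiproliferative activity against GTL 16 cell line (Homo sapiens), read by CCK-8 assay, with a stated time of 72 h; a higher number here means a weaker inhibitor, a lower number a stronger inhibitor:

Compound 1 `Cc1ccccc1C(=O)Nc1cccc(-c2oc3cc(-c4ccc(F)cc4)ccc3c(=O)c2O)c1` gives 24800 nM.
Compound 2 `O=C(Nc1cccc(-c2oc3cc(-c4ccc(F)cc4)ccc3c(=O)c2O)c1)c1ccc(C(F)(F)F)cc1` gives 33000 nM.
Compound 3 `Cc1cc(C(=O)Nc2cccc(-c3oc4cc(-c5ccc(F)cc5)ccc4c(=O)c3O)c2)ccc1F` gives 12100 nM.

Compound 2 stands at the highest of these three numbers. Its nearest neighbour is compound 1, reached by a 1.3-fold higher number from compound 1 to compound 2 (0.12 log units; within the scatter), a difference that stays within the scatter. Its furthest is compound 3, reached by a 2.7-fold lower number from compound 2 to compound 3 (0.44 log units; beyond the scatter), a modest but real change. All three compounds differ only in the aryl group attached to the carbonyl carbon of the amide, so the whole picture rests on that single position.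

Compound 4 `COc1ccc(C(=O)Nc2cccc(-c3oc4cc(-c5ccc(F)cc5)ccc4c(=O)c3O)c2)c(F)c1` carries the next variation at the same place: 2-fluoro-4-methoxyphenyl in place of 4-(trifluoromethyl)phenyl on a carbonyl carbon. Both measured steps from compound 2 bear on this, since each also swaps the aryl on the carbonyl carbon. One of them produced nothing beyond the scatter, the other a modest lowering of the number. A small to modest change in this assay therefore seems the likely size, with a lowering somewhat more probable than a rise, given the direction of a 2.7-fold lower number from compound 2 to compound 3 (0.44 log units; beyond the scatter).

For compound 4 the expected value is 20000 nM, within a range of 8000 nM to 50000 nM, which corresponds to an estimated step of a 1.7-fold lower number from compound 2 to compound 4 (0.22 log units; within the scatter).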

Compound 4, half-maximal inhibitory concentration: 15300 nM
Compound 4: the middle estimate sits 1.3-fold (0.12 log units) above what was measured; the range from low to high includes it.
By their numbers in this assay, from the lowest: compounds 3, 4, 1 and 2 (each within the scatter of the next, the first and the last beyond it).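

In this assay, the 2-fluoro-4-methoxyphenyl group is a second replacement for 4-(trifluoromethyl)phenyl on the carbonyl carbon that goes beyond the scatter, with a 2.2-fold lower number from compound 2 to compound 4 (0.33 log units; beyond the scatter) adding to the lowering already seen with compound 3. Compound 4 cannot be separated from the other two compounds, with a 1.3-fold higher number from compound 3 to compound 4 (0.10 log units; within the scatter) and a 1.6-fold lower number from compound 1 to compound 4 (0.21 log units; within the scatter) both staying within the scatter, so only compound 2 stands apart from it. The entering group carries one hydrogen-bond acceptor where the leaving group has none, but no measurement shown ties the step to that difference or to any other.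

As far as these compounds go, all four compounds carry a substituted phenyl ring on the carbonyl carbon, so it stays open whether a longer alkyl chain in its place, or a phenyl ring bearing an amine or a carboxylic acid, would shift the number further. It is also open which part of the new group matters, as the 2-fluoro and 4-methoxy substituents arrive together in compound 4 and no compound shown separates them.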